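A few compounds are considered here, and "the series" means these few. Any claim that something is new, unique, unknown or untested is made for them only; others in the source may bear on it.

Going by the values given here, compound 1 `CNS(=O)(=O)c1ccc(NC(=O)NCc2ccncc2)cc1` carries a methylamino sulfonamide on the shared core and in an assay on isolated protein for activation of Nicotinamide phosphoribosyltransferase (Homo sapiens) (a lower number here means that less compound is needed, a higher number that more compound is needed for the effect), compound 1 gives 3230 nM, the lowest of the two numbers measured so far. The nearest measured neighbour is compound 2 `CCOC(=O)c1ccc(NC(=O)NCc2cocn2)cc1`, which in this assay gives 27600 nM. Compound 3 `CCOC(=O)c1ccc(NC(=O)NCc2ccnnc2)cc1` reaches only a limit of this assay, > 100000 nM, and is not a number. Among the compounds with values here, the one step measured with a single change, an at least 3.6-fold higher number from compound 2 to compound 3 (0.55 log units; beyond the scatter), concerns the heteroaryl on the chain carbon bound to the urea nitrogen and is backed by the limit of > 100000 nM in this assay, at which 1 of the 3 values shown sits; it says nothing about the sulfonamide end of the molecule. Compound 4 `CN(Cc1ccccc1)S(=O)(=O)c1ccc(NC(=O)NCc2ccncc2)cc1` differs from compound 1 only there: benzyl in place of hydrogen on a sulfonamide nitrogen. Within the data shown here, no measured step touches a sulfonamide nitrogen, so no direction can be read from the series. The working expectation for compound 4 is therefore a number close to compound 1, with a step of a 1.1-fold lower number from compound 1 to compound 4 (0.03 log units; within the scatter), and the estimate for compound 4 is 3000 nM, within 800 nM to 12000 nM.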

Compound 4, half-maximal effective concentration: 23 nM
For compound 4 the middle estimate is 130-fold (2.12 log units) above the measured one, and the stated range ends above it.
By their numbers in this assay, from the lowest: compound 4; then compound 1; then compound 2. At a limit, above all of these: compound 3.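

In this assay, going by these compounds alone, there is a 140-fold lower number from compound 1 to compound 4 (2.15 log units; beyond the scatter) at the sulfonamide nitrogen, so this end of the molecule, untouched by the earlier steps, responds strongly to substitution. A nitrogen carrying benzyl and methyl, with no hydrogen left on it, therefore gives a lower number than the methylamino group of compound 1, and the hydrogen on this nitrogen is not needed for activity in this pair. Within the data shown here, nothing measured so far bears on the cause of this step.

As far as these compounds go, whether the gain needs the aromatic ring or only a larger group on this nitrogen stays open, since a cyclohexylmethyl or a plain butyl chain would separate the two. Also open, from the compounds shown here alone, is whether a longer link such as phenethyl, or a second benzyl in place of the methyl, goes further still.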